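Dichlorophenyl swap on the urea of compound 3

The source may hold more compounds than are shown below. What is called first, only, known or untested is meant among the compounds shown, and "the series" means these compounds.

Three members of the series have numbers in a functional assay on A375P cells (Homo sapiens) for cytotoxicity, read by MTT assay; on this read-out higher numbers stand for weaker inhibition and lower numbers for stronger inhibition. Compound 1 `O=C(Nc1ccc(-n2ccc3nc(C(=O)NCc4ccccc4)ccc32)cc1)Nc1cccc(Cl)c1Cl` gives only a limit in this assay, > 10000 nM. Compound 2 `COC(=O)c1ccc2c(ccn2-c2ccc(NC(=O)Nc3cccc(Cl)c3Cl)cc2)n1` gives 6400 nM; the step of an at least 1.5-fold lower number from compound 1 to compound 2 (0.19 log units; that floor lies within the scatter) cannot be sized further because of the limit of > 10000 nM in this assay, at which 1 of the 3 values shown sits. Compound 3 `NC(=O)c1ccc2c(ccn2-c2ccc(NC(=O)Nc3ccc(Cl)c(Cl)c3)cc2)n1` gives 3200 nM, the lowest of the two numbers, though compound 2 lies within the scatter of it.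

Compound 4 `NC(=O)c1ccc2c(ccn2-c2ccc(NC(=O)Nc3cccc(Cl)c3Cl)cc2)n1` differs from compound 3 by 2,3-dichlorophenyl in place of 3,4-dichlorophenyl on an amide-type nitrogen. Among the compounds with values here, no measured step isolates this swap: the only measured step concerns the substituent on the carbonyl carbon, and compounds 1 and 2 carry 2,3-dichlorophenyl while differing from compound 4 there as well. The number for compound 4 is therefore expected to sit near that of compound 3 or somewhat higher, a step of a 1.9-fold higher number from compound 3 to compound 4 (0.27 log units; within the scatter). Compound 4 is estimated at 6000 nM, within 2000 nM to 20000 nM.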

Compound 4, half-maximal inhibitory concentration: 4600 nM
The estimate for compound 4 lay 1.3-fold (0.12 log units) above the measured number; low and high end bracket the measured number.
By their numbers in this assay, from the lowest: compounds 3, 4 and 2 (each within the scatter of the next). At a limit, above all of these: compound 1.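

On an amide-type nitrogen, 2,3-dichlorophenyl in place of 3,4-dichlorophenyl now has a step of its own, a 1.4-fold higher number from compound 3 to compound 4 (0.16 log units; within the scatter), so in this assay the two chlorine patterns cannot be told apart. Within the data shown here, on a carbonyl carbon, amino in place of methoxy is likewise unresolved, a 1.4-fold lower number from compound 2 to compound 4 (0.14 log units; within the scatter), while hydrogen in place of benzyl on the amide-type nitrogen gives the only step beyond the scatter, an at least 2.1-fold lower number from compound 1 to compound 4 (0.33 log units; beyond the scatter). Compound 1 stands at a limit, so this step is only a floor: the limit of > 10000 nM in this assay, at which 1 of the 4 values shown sits.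

Still open, from the compounds shown here alone, is whether a carboxylic acid on the carbonyl carbon would separate from these values. The same holds for a single chlorine or a trifluoromethyl group on the phenyl ring of the urea.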